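The source may hold more compounds than are shown below. What is called first, only, known or untested is meant among the compounds shown, and "the series" means these compounds.

Compound 1 `CCCC/C=C\CCCCCCCCCc1cc(=O)c2c(O)cc(O)c(C)c2o1` was tested in a functional assay on MDA-MB-231 cells (Homo sapiens) for antiproliferative activity, read by MTT assay (a higher number here means a weaker inhibitor, a lower number a stronger inhibitor), and there compound 1 gives 6790 nM. Compound 2 `CCCCC/C=C\C/C=C\CCCCCCCC1(O)CC(=O)c2c(O)cc(O)cc2O1` sits beside it; in this assay compound 2 gives 6790 nM, so compound 1 stands level with compound 2, the two values lying within the usual scatter. Among the measured compounds shown here, no pair of measured compounds differing in a single place is available, so nothing yet shows how one change moves the number. Compound 3 `CCCCCCCCCCCCCCCc1cc(=O)c2c(O)cc(O)c(C)c2o1` differs from compound 1 in one way: hexyl in place of hex-1-en-1-yl on a saturated chain carbon, nine bonds along the chain from an aromatic carbon. With hexyl in place of hex-1-en-1-yl so far along the chain, the step of a 1.0-fold higher number from compound 1 to compound 3 (0.00 log units; within the scatter) is expected to be none beyond the scatter. Compound 3 is therefore expected to give about 6800 nM, within a range from 3000 nM to 15000 nM.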

Compound 3, half-maximal inhibitory concentration: 6790 nM
For compound 3 the middle estimate is 1.0-fold (0.00 log units) above the measured one; low and high end bracket the measured number.
By their numbers in this assay, from the lowest: compounds 1, 2 and 3 (each within the scatter of the next).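

Swapping hex-1-en-1-yl for hexyl gives no change at the digits printed from compound 1 to compound 3 (within the scatter) in this assay and provides the first comparison of two compounds that differ in one place. At this saturated chain carbon, nine bonds along the chain from an aromatic carbon, removing the double bond outside the aromatic rings leaves the number unchanged at the digits printed. No measurement on hand gives a reason for this. On these data alone, whether in this assay a shorter chain, or an amine or a carboxylic acid in place of hexyl, would move the number stays open.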